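Piperidin-1-yl replacing 4-(pyridin-2-yl)piperazin-1-yl in the series

The source may report more compounds than this note shows. Statements on the series, on what has been measured and on what is new or still open speak of the compounds shown alone.

In a functional assay on A549 cells (Homo sapiens) for inhibition, with a stated time of 72 h (a higher number here means a weaker inhibitor, a lower number a stronger inhibitor), compound 1 `O=C(Nc1ccccc1)Nc1nc(Nc2ccccc2)cc(Sc2c[nH]c3ccccc23)n1` reads > 50000 nM as a limit of the assay and not a number. Among the measured compounds shown here, compound 2 `O=C(Nc1ccccc1)Nc1nc(Sc2c[nH]c3ccccc23)cc(N2CCN(c3ccccn3)CC2)n1` gives 30300 nM in this assay and so holds the only actual number so far.

Compound 3 `O=C(Nc1ccccc1)Nc1nc(Sc2c[nH]c3ccccc23)cc(N2CCCCC2)n1` differs from compound 2 in one place, with piperidin-1-yl in place of 4-(pyridin-2-yl)piperazin-1-yl on an aromatic carbon of the shared core (piperidin-1-yl in place of 4-(pyridin-2-yl)piperazin-1-yl on an aromatic carbon). For the measured compounds named here, only one measured step bears on this change. It is an at least 1.6-fold lower number from compound 1 to compound 2 (0.21 log units; that floor lies within the scatter) with 4-(pyridin-2-yl)piperazin-1-yl in place of anilino on the same aromatic carbon. The floor of that step stays within the scatter and its full size is open, so it gives no firm measure for the group that now leaves.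

No step beyond the scatter is therefore expected in this assay in either direction, and a report of compound 3 only as a limit remains possible. Compound 3 is expected near 28000 nM with an estimated range from 11000 nM to 50000 nM in this read-out. The estimate means a 1.1-fold lower number from compound 2 to compound 3 (0.03 log units; within the scatter) as the expected step.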

Compound 3, half-maximal inhibitory concentration: 33100 nM
Compound 3: the middle estimate sits 1.2-fold (0.07 log units) below what was measured; the range from low to high includes it.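

In this assay, piperidin-1-yl in place of 4-(pyridin-2-yl)piperazin-1-yl on this aromatic carbon gives a 1.1-fold higher number from compound 2 to compound 3 (0.04 log units; within the scatter), so a group without the six-membered aromatic ring reads within the scatter of the larger group at this position. Among the compounds shown here, in place of anilino on the same carbon, piperidin-1-yl gives an at least 1.5-fold lower number from compound 1 to compound 3 (0.17 log units; that floor lies within the scatter), a floor that, like the one for the larger group, does not leave the scatter. Compound 1 stands at a limit of the assay and not at a number, and the full size of both steps from it cannot be read because of this: the limit of > 50000 nM in this assay, at which 1 of the 3 values shown sits.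

On these data alone, whether any group on this carbon, such as a dimethylamino group, a morpholin-4-yl ring or a piperazine carrying a carboxylic acid on a short chain, gives a step beyond the scatter remains open. Also open is how the number in this assay responds to changes in the (1H-indol-3-yl)sulfanyl and (phenylcarbamoyl)amino groups, which stay the same across the compounds shown.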